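Swapping the amide group on a compound at the limit

The source may hold more compounds than are shown below. What is called first, only, known or untested is meant among the compounds shown, and "the series" means these compounds.

In a physicochemical assay for solubility, read by HPLC, using the shake flask method, in phosphate buffer, measured as kinetic solubility, with a stated time of 20 h, at pH 6.5 (on this read-out lower numbers stand for lower solubility and higher numbers for higher solubility), compound 1 (`C[C@H]1CN(c2ccc(Nc3nc4cnc(Nc5cccc(C(F)(F)F)c5)cc4[nH]3)nc2)CCN1`) gives 180000 nM. In this assay compound 2 (`O=C(c1ccnc(Nc2nc3cnc(Nc4ccc(F)c(C(F)(F)F)c4)cc3[nH]2)c1)N1CCN(C2CC2)CC1`) gives < 5000 nM, which is a limit of the assay and not a number. Compound 2 therefore stands at the limit of < 5000 nM in this assay, at which 1 of the 2 values shown sits. Within the data shown here, the two measured compounds do not form a single-place step, so no measured step gives a size for the change considered here.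

Compound 3 (`C[C@@H]1CN(C(=O)c2ccnc(Nc3nc4cnc(Nc5ccc(F)c(C(F)(F)F)c5)cc4[nH]3)c2)C[C@H](C)O1`) has 2,6-dimethylmorpholin-4-yl in place of 4-cyclopropylpiperazin-1-yl on a carbonyl carbon, (2,6-dimethylmorpholin-4-yl in place of 4-cyclopropylpiperazin-1-yl on a carbonyl carbon). The rest of its structure is that of compound 2.

Among the measured compounds shown here, with no measured precedent for this exchange, the working expectation is a small downward movement, close to the usual scatter of the assay. The expected change is a step that the limit leaves unreadable from compound 2 to compound 3. This expectation is anchored only on compound 2, with its limit of < 5000 nM, so it is loose, and another limit rather than a number is the more likely report. For compound 3 the estimated solubility is 2500 nM, with an expected range of 600 nM to 8000 nM.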

Compound 3, solubility: < 5000 nM
Compound 3 was reported as a limit; the forecaster's own chance of this, stated with the estimate: 65%; the middle value is on the limit's open side.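

Compound 2 and compound 3 are both reported as limits of the assay and not as numbers, so no step can be read between them: the limit of < 5000 nM in this assay, at which 2 of the 3 values shown sit. The compounds shown leave open the size and direction of any change in solubility when 2,6-dimethylmorpholin-4-yl takes the place of 4-cyclopropylpiperazin-1-yl on a carbonyl carbon.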